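A few compounds are considered here, and "the series" means these few. Any claim that something is new, unique, unknown or untested is made for them only; others in the source may bear on it.

Compound 2, with the structure `CC[C@@H]1C(=O)N(C)c2cnc(-n3ccc4cc(C(=O)NC5CCCC5)ccc43)nc2N1C1CCCC1`, and compound 1, with the structure `CC[C@@H]1C(=O)N(C)c2cnc(-n3ccc4cc(C(N)=O)ccc43)nc2N1C1CCCC1`, share one core and differ at a single point. In a functional assay on MCF7 cells (Homo sapiens) for antiproliferative activity, read by CCK-8 assay, with a stated time of 72 h (on this read-out lower numbers stand for stronger inhibition of growth and higher numbers for weaker inhibition of growth), compound 2 gives 795 nM, while compound 1 gives 1830 nM. The change between them is hydrogen in place of cyclopentyl on an amide-type nitrogen, and it produced a 2.3-fold higher number from compound 2 to compound 1 (0.36 log units; beyond the scatter).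

Compound 3, with the structure `CCC1C(=O)N(C)c2cnc(-n3ccc4cc(C(=O)NC5CCCC5)ccc43)nc2N1c1ccn(C)n1`, carries the same cyclopentylcarbamoyl group as compound 2 but on a different core; the difference between the two cores is not broken down here. In this assay compound 3 was reported as "not active" (no number reported), and no number was given for it.

Compound 4, with the structure `CCC1C(=O)N(C)c2cnc(-n3ccc4cc(C(N)=O)ccc43)nc2N1c1ccn(C)n1`, has not yet been measured. It stands to compound 3 as compound 1 stands to compound 2: the change is hydrogen in place of cyclopentyl on an amide-type nitrogen, the same kind of change at the same place, on an amide-type nitrogen whose other neighbour is a carbonyl carbon. Among the measured compounds shown here, in the one measured pair this change made the number higher, beyond the usual scatter, as seen in a 2.3-fold higher number from compound 2 to compound 1 (0.36 log units; beyond the scatter). Since compound 3 itself gave no measurable number, the starting point for compound 4 is already at or beyond the reach of this assay, and the change is expected to push it further in the same direction. Compound 4 is therefore expected to give about 20000 nM in this assay, within roughly 5000 nM to 80000 nM, with a high chance that only a limit is reported.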

Compound 4, concentration for 50% growth inhibition: "not active" (no number reported)
Nothing numeric was reported for compound 4; no gap can be computed for the estimate.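

In this assay, among the compounds shown here, compound 3 gives "not active" (no number reported) and compound 4 gives "not active" (no number reported) and so no step between the two can be read. The compounds shown leave open whether hydrogen in place of cyclopentyl changes growth inhibition at all on the core of compound 3. Nothing given here offers an explanation for this result.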